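Series notes: alkyl extension on two cores, compound 4 pending

The source may hold more compounds than are shown below. What is called first, only, known or untested is meant among the compounds shown, and "the series" means these compounds.

Measured so far:
- compound 1, `Cc1ccc(CN2CCCNC2=S)cc1`, gives 5100 nM in a functional assay on B16 cells (Mus musculus) for inhibition, with a stated time of 72 h; a higher number here means a weaker inhibitor, a lower number a stronger inhibitor.
- compound 2, `CCc1ccc(CN2CCCNC2=S)cc1`, gives 1300 nM in this assay.
- compound 3, `CCc1ccc(CN2CCCNC2=O)cc1`, gives > 10000 nM in this assay, which is a limit of the assay and not a number.

Compound 3 sits at the limit of > 10000 nM in this assay, at which 1 of the 3 values shown sits. Between compound 1 and compound 2 the change is methyl in place of hydrogen on a saturated chain carbon bound to an aromatic carbon, and it brought a 3.9-fold lower number from compound 1 to compound 2 (0.59 log units; beyond the scatter). Among the measured compounds shown here, how the core of compound 3 differs from the core of compound 1 is not broken down here; the two values show only that compound 3 is weaker than the limit allows one to say, while compound 2 is well inside the measured range.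

Compound 4, `CC(C)c1ccc(CN2CCCNC2=O)cc1`, is not yet measured. Its difference from compound 3 is methyl in place of hydrogen on a saturated chain carbon bound to an aromatic carbon and a saturated chain carbon. This is the same kind of change as the step from compound 1 to compound 2, not the same: here the place is on a saturated chain carbon bound to an aromatic carbon and a saturated chain carbon, whereas before it was on a saturated chain carbon bound to an aromatic carbon only. The expectation rests on compound 1 and compound 2, where the step of a 3.9-fold lower number from compound 1 to compound 2 (0.59 log units; beyond the scatter) was modest, and on compound 3 giving only a limit, > 10000 nM. A step of about an at least 1.2-fold lower number from compound 3 to compound 4 (0.09 log units; that floor lies within the scatter) is expected. Compound 4 is estimated at 8000 nM, within 2500 nM to 30000 nM, with a fair chance that only a limit is reported.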

Compound 4, half-maximal inhibitory concentration: > 10000 nM
Compound 4: a limit, no number; the forecaster's own chance of this, stated with the estimate: 45%; middle value at least 1.2-fold (0.09 log units) from the limit.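

Compound 3 and compound 4 both give only a limit of the assay in this assay, not a number, so no step between them can be read: the limit of > 10000 nM in this assay, at which 2 of the 4 values shown sit.

The compounds shown leave open whether ethyl to isopropyl changes the number at all on the core of compound 3, and how the same change would read on the core of compound 2.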